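Cytotoxicity notes: a 4-methoxybenzyl analogue of compound 1

The source may report more compounds than this note shows. Statements on the series, on what has been measured and on what is new or still open speak of the compounds shown alone.

Measured in a functional assay on MDA-MB-231 cells (Homo sapiens) for cytotoxicity, read by MTT assay, with a stated time of 72 h; a higher number here means a weaker inhibitor, a lower number a stronger inhibitor:
- compound 1 `N=C(Nc1cccc(C(F)(F)F)c1)c1cc2c(-c3ccccc3)n[nH]c2cn1` gives 22300 nM
- compound 2 `Cn1nc(-c2ccccc2)c2cc(C(=N)Nc3ccccc3)ncc21` gives 11100 nM
- compound 3 `N=C(Nc1ccccc1)c1cc2cn[nH]c2cn1` reaches only a limit of the assay, > 50000 nM

Compound 1 and compound 2 sit within the scatter of each other in this assay. The value of compound 3 is a limit only (the limit of > 50000 nM in this assay, at which 1 of the 3 values shown sits). Compound 4 `COc1ccc(Cn2nc(-c3ccccc3)c3cc(C(=N)Nc4cccc(C(F)(F)F)c4)ncc32)cc1` differs from compound 1 by 4-methoxybenzyl in place of hydrogen on an aromatic nitrogen. Among the compounds with values here, no measured pair isolates this change, so its size is open; a modest drop in number, somewhat beyond the scatter, is the expectation for compound 4. The estimated step from compound 1 to compound 4 is a 2.8-fold lower number from compound 1 to compound 4 (0.45 log units; beyond the scatter). Compound 4 is expected at 8000 nM, between 2500 nM and 30000 nM.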

Compound 4, half-maximal inhibitory concentration: > 50000 nM
Compound 4: no number, only a limit (the forecaster's own chance of this, stated with the estimate: 10%); at least 6.2-fold (0.79 log units) between middle value and limit.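

In this assay compound 4 reaches only a limit, > 50000 nM. Within the data shown here, the change to 4-methoxybenzyl on this aromatic nitrogen brings an at least 2.2-fold higher number from compound 1 to compound 4 (0.35 log units; beyond the scatter), the first step at this position that isolates one change, and it runs toward weaker inhibition. Its full size cannot be read, as compound 4 sits at the assay limit: the limit of > 50000 nM in this assay, at which 2 of the 4 values shown sit.

Going by these compounds, whether a plain benzyl or an aminoethyl chain on this nitrogen would hold the level of compound 1 remains open. Methyl on this nitrogen with the trifluoromethyl group kept in place also remains open.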